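A Smaller Ester at the Assay Limit

This account rests on a few compounds, and the source may have more. Where it says the series, first, only, none or still open, it means among the compounds named here.

Measured in an ADME assay on HeLa cells (Homo sapiens) for cytotoxicity, read by MTT assay, with a stated time of 2 days (a higher number here means that more compound is tolerated, a lower number that less compound is tolerated), so far:
Compound 1 `CCOC(=O)c1cc2ccc(Oc3ccnc(C(=O)NC)c3)cc2s1` gives > 100000 nM as a limit, not a number
Compound 2 `CCOC(=O)c1sc2cc(Oc3ccnc(C(=O)NC)c3)ccc2c1C` gives > 100000 nM as a limit, not a number
Compound 3 `CCOC(=O)c1sc2cc(Oc3ccnc(C(=O)NC)c3)ccc2c1CC` gives 16700 nM as a number

Compound 1 stands at the limit of > 100000 nM in this assay, at which 2 of the 3 values shown sit, and so offers no number to start from.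

Compound 4 `CNC(=O)c1cc(Oc2ccc3cc(C(=O)OC)sc3c2)ccn1` differs from it only in the ester: hydrogen in place of methyl on a saturated chain carbon bound to an oxygen next to a carbonyl group with hydrogen in place of methyl on a saturated chain carbon bound to an oxygen next to a carbonyl group, so ethoxycarbonyl becomes methoxycarbonyl.

For the measured compounds named here, no measured step touches the ester. The nearest are changes that add methyl or ethyl on the shared core. These are a step that the two limits leave unreadable from compound 1 to compound 2 and an at least 5.9-fold lower number from compound 1 to compound 3 (0.77 log units; beyond the scatter) and also an at least 5.9-fold lower number from compound 2 to compound 3 (0.77 log units; beyond the scatter) for the further methyl. Only compound 3 left the limit, while compound 2 did not.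

Compound 4 loses a methyl instead of gaining one, and at another place, so these steps carry over only loosely and no fall in this assay is expected. The expected result is a number no higher from compound 1 to compound 4 (the limit leaves the size open) with nothing foreseen beyond the scatter. For compound 4 the estimate is 100000 nM with an expected range from 40000 nM to 250000 nM and another limit is the likeliest report.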

Compound 4, half-maximal cytotoxic concentration: 68300 nM
Estimate against measurement, compound 4: 1.5-fold (0.17 log units) above, and the stated range covers the measured number.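

For the compounds shown here, no compound before compound 4 changed the ester, and here the change from ethoxycarbonyl to methoxycarbonyl gives a number in this assay where the earlier ester gave only a limit, a step that reads an at least 1.4-fold lower number from compound 1 to compound 4 (0.16 log units; that floor lies within the scatter). That reading is only a floor and does not establish a real fall at this position, since the value for compound 1 is not a number: the limit of > 100000 nM in this assay, at which 2 of the 4 values shown sit. The step also shows that a methyl does not count the same at every place on these compounds, as adding it to a saturated chain carbon bound to an aromatic carbon and adding it to one bound to an oxygen next to a carbonyl group do not read alike: the same change on two cores in this assay, an at least 5.9-fold lower number (0.77 log units; beyond the scatter) from compound 2 to compound 3 and an at least 1.4-fold higher number (0.16 log units; that floor lies within the scatter) from compound 4 to compound 1, at least 8.7-fold (0.94 log units) apart, beyond the scatter of two such steps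

From the compounds shown here alone, the true distance between the two esters remains open, as does whether methoxycarbonyl would keep this reading on a core carrying the methyl of compound 2 or the ethyl of compound 3. Also open, going by these compounds, is how this assay would read with a carboxylic acid in place of the ester, or with a longer chain such as propyl on the ester oxygen.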